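The compounds below may be only part of what the source reports. "The series", "measured", "known", "first", "only" and "open" are said of these compounds alone.

Working notes on the series in a functional assay on MT4 cells (Homo sapiens) for antiproliferative activity, read by MTT assay, with a stated time of 96 h; on this read-out lower numbers stand for an effect already at smaller amounts and higher numbers for an effect only at larger amounts of compound. Going by the values given here, compound 1 `N#C/C(=C\c1c(-c2ccccc2)[nH]c2ccccc12)C(=O)N1CCCCC1` gives 9600 nM, the only number in hand so far. Compound 2 `N#C/C(=C\c1c[nH]c2ccccc12)S(=O)(=O)c1ccccc1` returns only a limit of the assay, > 100000 nM. (the limit of > 100000 nM in this assay, at which 1 of the 2 values shown sits). Compound 3 `N#C/C(=C\c1c(-c2ccccc2)[nH]c2ccccc12)C(=O)c1ccc(Cl)cc1` differs from compound 1 by 4-chlorophenyl in place of piperidin-1-yl on a carbonyl carbon. Among the compounds with values here, no measured step covers such a change, so the size of the move is expected rather than known: a modest shift toward an effect at smaller amounts, not clearly beyond the usual scatter, expressed as a 1.9-fold lower number from compound 1 to compound 3 (0.28 log units; within the scatter). Compound 3 is estimated at 5000 nM, within a range of 1000 nM to 30000 nM.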

Compound 3, half-maximal effective concentration: 400 nM
Beside the measured number, compound 3's estimate is 13-fold (1.10 log units) above it; the measured number lies below the stated range.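

In this assay, going by these compounds alone, the substituent on this carbonyl carbon proves to matter strongly: 4-chlorophenyl in place of piperidin-1-yl gives a 24-fold lower number from compound 1 to compound 3 (1.38 log units; beyond the scatter), the first measured step. The piperidin-1-yl group is therefore not required at this place for an effect at smaller amounts. Nothing in hand gives a cause for this step. From the compounds shown here alone, it remains open whether the chlorine contributes or the phenyl ring alone suffices, so plain phenyl and 4-methoxyphenyl are the obvious comparisons. Going by these compounds, how morpholin-4-yl would read at this carbonyl carbon also remains open.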